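One nitrooxy fewer: compound 3 against compound 1

The compounds below may be only part of what the source reports. "The series", "measured", "known", "first", "only" and "open" are said of these compounds alone.

Compound 1 `Cc1cc(OC(=O)c2ccc(CC(CO[N+](=O)[O-])O[N+](=O)[O-])cc2)n(-c2ccccc2)n1` gives < 0.0167 h
Compound 2 `Cc1cc(OC(=O)CCCCCO[N+](=O)[O-])n(-c2ccccc2)n1` gives < 0.0167 h

In an ADME assay on liver (Rattus norvegicus, strain Wistar) for metabolic stability, read by HPLC, tested at 200 uM (on this read-out lower numbers stand for a shorter-lived compound and higher numbers for a longer-lived compound), compound 1 gives < 0.0167 h, which is a limit of the assay and not a number. Compound 2 gives < 0.0167 h, and this too is only a limit. Compound 1 therefore stands at the limit of < 0.0167 h in this assay, at which 2 of the 2 values shown sit. Within the data shown here, neither compound has a measured number, and no measured step connects any two compounds.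

Compound 3 `Cc1cc(OC(=O)c2ccc(CCCO[N+](=O)[O-])cc2)n(-c2ccccc2)n1` comes from compound 1 by one change: hydrogen in place of nitrooxy on a saturated chain carbon bound to two saturated chain carbons. The side chain thus goes from 1,2-bis(nitrooxy)ethyl to 2-(nitrooxy)ethyl.

Among the measured compounds shown here, with no measured step to scale this change, no shift in either direction beyond the usual scatter is expected in this assay, and compound 3 will quite likely be reported as a limit too. The expected size of the change is a step that the limit leaves unreadable from compound 1 to compound 3. Compound 3 is estimated at 0.015 h, with an expected range from 0.005 h to 0.05 h.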

Compound 3, half-life in the liver assay: < 0.0167 h
Compound 3 gave a limit, no number; the forecaster's own chance of this, stated with the estimate: 85%; the middle value does not contradict the limit.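

In the liver assay compound 3 gives < 0.0167 h, which is a limit of the assay and not a number. Among these compounds, compound 1 also gives only a limit, so no step from compound 1 to compound 3 can be read. The compounds shown leave open whether hydrogen in place of nitrooxy alters the half-life at all, since all three rest at one value: the limit of < 0.0167 h in the liver assay, at which 3 of the 3 values shown sit.

In a physicochemical assay for lipophilicity, read by HPLC, measured as octanol-water partition, at pH 7 (on this read-out lower numbers stand for lower lipophilicity and higher numbers for higher lipophilicity), compound 1 gives 4.88 and compound 3 gives 4.76. This is a number 0.12 log units lower from compound 1 to compound 3 (within the scatter).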